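Indanyl-piperazine series: chain length and indanyl attachment point

The source may hold more compounds than are shown below. What is called first, only, known or untested is meant among the compounds shown, and "the series" means these compounds.

Measured so far in an assay for activation of Adrenergic receptor alpha-1 (Rattus norvegicus); on this read-out higher numbers stand for an effect only at larger amounts of compound and lower numbers for an effect already at smaller amounts:
compound 1 `c1ccc2c(c1)CCC2CCN1CCN(c2cccc3c2OCCO3)CC1` gives 4.01 mg/kg
compound 2 `c1ccc2c(c1)CCC2CCCN1CCN(c2cccc3c2OCCO3)CC1` gives 0.23 mg/kg
compound 3 `c1ccc2c(c1)CC(CCN1CCN(c3cccc4c3OCCO4)CC1)C2` gives 0.66 mg/kg

Compound 2 has the lowest number of the three; its nearest neighbour is compound 3, and compound 1 lies furthest from it. The difference between the cores of compound 1 and compound 2 is not broken down here. From compound 1 to compound 3 the change is 2,3-dihydro-1H-inden-2-yl in place of 2,3-dihydro-1H-inden-1-yl on a saturated chain carbon, two bonds along the chain from an amine nitrogen in a ring, and it gave a 6.1-fold lower number from compound 1 to compound 3 (0.78 log units; beyond the scatter).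

Compound 4 `c1ccc2c(c1)CC(CCCN1CCN(c3cccc4c3OCCO4)CC1)C2` awaits measurement in this assay. It differs from compound 2 by 2,3-dihydro-1H-inden-2-yl in place of 2,3-dihydro-1H-inden-1-yl on a saturated chain carbon, three bonds along the chain from an amine nitrogen in a ring. This is the same kind of change as from compound 1 to compound 3, though the place is not identical: there it was two bonds along the chain from the amine nitrogen, here three. For the measured compounds named here, for compound 4 the step of a 2.3-fold lower number from compound 2 to compound 4 (0.36 log units; beyond the scatter) is expected to be somewhat smaller than the earlier one, because compound 2 already sits at 0.23 mg/kg and only a single example of this change is known. Compound 4 is therefore estimated at 0.1 mg/kg, expected to fall between 0.03 mg/kg and 0.4 mg/kg.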

Compound 4, dose for half-maximal effect: 1.73 mg/kg
Compound 4: the middle estimate sits 17-fold (1.24 log units) below what was measured; the whole stated range lies below it.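

In this assay, 2,3-dihydro-1H-inden-2-yl in place of 2,3-dihydro-1H-inden-1-yl, three bonds along the chain from an amine nitrogen in a ring, gave a 7.5-fold higher number from compound 2 to compound 4 (0.88 log units; beyond the scatter). The change does not carry from one core to the other in this series, and its direction reverses: the same change on two cores in this assay, a 6.1-fold lower number (0.78 log units; beyond the scatter) from compound 1 to compound 3 and a 7.5-fold higher number (0.88 log units; beyond the scatter) from compound 2 to compound 4, 46-fold (1.66 log units) apart, beyond the scatter of two such steps With one pair on each core, this shows that the outcome of the change depends on the core, but not which feature of the cores is responsible or how the change would behave on a further core.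

The compounds shown leave open how either indanyl attachment behaves on a longer chain. They also leave open whether a phenyl group in place of the indanyl group would show the same reversal.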